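A few compounds are considered here, and "the series" means these few. Any claim that something is new, unique, unknown or untested is made for them only; others in the source may bear on it.

Of the compounds shown here, two with a shared core have been measured so far. Compound 1 `O=C(CSc1nc2ccccc2s1)N/N=C/c1ccc(Oc2ccc(Cl)cc2)cc1` and compound 2 `Cc1cc(Oc2ccc(/C=N/Nc3nc4ccccc4s3)cc2)ccc1Cl` were examined in a physicochemical assay for lipophilicity, in phosphate buffer, measured as octanol-water partition, with a stated time of 24 h; a higher number here means a more lipophilic compound, a lower number a more polar compound. Compound 1 gives 5.6 in this assay, and compound 2 gives 5.5. Compound 1 has the higher of the two numbers, yet the gap to compound 2 lies within the usual scatter of repeated measurements, so the two cannot be told apart on these data alone. Within the data shown here, no pair of measured compounds differing in a single place is available, so there is no measured step to lean on.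

The next compound, compound 3 `O=C(CSc1nc2ccccc2s1)N/N=C/c1ccc(Oc2ccc([N+](=O)[O-])cc2)cc1`, has not yet been measured in this assay. Compared with compound 1 it carries a change at one place only: nitro in place of chloro on an aromatic carbon. Among the measured compounds shown here, since no measured step describes this kind of change, the expectation rests on the structural change itself. Compound 3 is expected to give a lower number than compound 1, with a step of a number 0.90 log units lower from compound 1 to compound 3 (beyond the scatter) that should lie beyond the scatter. The estimate for compound 3 in this assay is 4.7, in a range from 4.2 to 5.2.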

Compound 3, partition coefficient: 5.3
Beside the measured number, compound 3's estimate is 0.60 log units below it, and the stated range ends below it.
By their numbers in this assay, from the lowest: compounds 3, 2 and 1 (each within the scatter of the next).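

Among these compounds, the first measured step at this position comes from the exchange of 4-chlorophenoxy for 4-nitrophenoxy, where nitro takes the place of chloro on an aromatic carbon para to a large group. In this assay this exchange gives a number 0.30 log units lower from compound 1 to compound 3 (within the scatter) and so leaves compound 1 and compound 3 indistinguishable on these data. The change is not a small one on paper, since a single chlorine atom leaves and three heavy atoms enter with two hydrogen-bond acceptors, yet this larger group with its added acceptors produces no step that stands clear of the scatter, and nothing measured here explains that outcome.

This single pair cannot show whether the same position would stay as unresponsive with an amine or a carboxylic acid in place of chloro, and either group would test the position with a more demanding change. Nor can it show whether nitro in place of chloro would give a similar step on a different core, or at a different place on the shared core.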